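From tert-butyl to 1,1,2-trimethylpropyl at the assay limit

This account rests on a few compounds, and the source may have more. Where it says the series, first, only, none or still open, it means among the compounds named here.

Compound 1 `CC(C)C(C)(C)[Si](C)(C)OC[C@H]1O[C@@H](n2ccc(=O)[nH]c2=O)[C@H](O)[C@@H]1O` and compound 2 `Cc1cn([C@@H]2O[C@H](CO[Si](C)(C)C(C)(C)C)[C@@H](O)[C@H]2O)c(=O)[nH]c1=O` were both examined in a functional assay on U-373MG ATCC cells (Homo sapiens) for inhibition, read by MTT assay, with a stated time of 72 h; on this read-out higher numbers stand for weaker inhibition of growth and lower numbers for stronger inhibition of growth. Compound 1 gives > 100000 nM, which is a limit of the assay and not a number. Compound 2 gives > 100000 nM, again a limit and not a number. Compound 2 therefore has no exact position on the scale, and the two results together amount to the limit of > 100000 nM in this assay, at which 2 of the 2 values shown sit.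

Compound 3 `Cc1cn([C@@H]2O[C@H](CO[Si](C)(C)C(C)(C)C(C)C)[C@@H](O)[C@H]2O)c(=O)[nH]c1=O` differs from compound 2 by isopropyl in place of methyl on a saturated chain carbon bound to two saturated chain carbons and a silicon atom. This is isopropyl in place of methyl on a saturated chain carbon bound to two saturated chain carbons and a silicon atom, so that tert-butyl becomes 1,1,2-trimethylpropyl. Within the data shown here, no measured pair gives the size of this change. The expectation therefore rests on compound 2 alone, at > 100000 nM. The expected a number no higher from compound 2 to compound 3 (the limit leaves the size open) is no shift beyond the scatter in either direction, and another limit is the likeliest report. For compound 3 the estimated value is 100000 nM, with an expected range from 50000 nM to 200000 nM.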

Compound 3, concentration for 50% growth inhibition: 68000 nM
Compound 3: middle estimate off by 1.5-fold (0.17 log units), on the high side; the range from low to high includes it.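

In this assay compound 3 gives 68000 nM, the first result in this set that is a number and not a limit of the assay. The change from tert-butyl to 1,1,2-trimethylpropyl gives an at least 1.4-fold lower number from compound 2 to compound 3 (0.16 log units; that floor lies within the scatter), so only a floor can be stated for isopropyl in place of methyl at this carbon, and that floor does not establish an effect of the change. Methyl in place of hydrogen on an aromatic carbon is likewise bounded from one side only, with an at least 1.4-fold lower number from compound 1 to compound 3 (0.16 log units; that floor lies within the scatter), and the set as a whole still sits mostly at the top of the scale: the limit of > 100000 nM in this assay, at which 2 of the 3 values shown sit.

As far as these compounds go, compound 1 and compound 2 have no exact place on the scale, so the true size of both steps remains open. Also open, from the compounds shown here alone, is what a longer chain such as n-butyl, or an amine, would give in place of isopropyl on a saturated chain carbon bound to two saturated chain carbons and a silicon atom.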